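Cyano in place of hydroxymethyl on the shared core

This account rests on a few compounds, and the source may have more. Where it says the series, first, only, none or still open, it means among the compounds named here.

In an ADME assay on HEK-293T cells (Homo sapiens) for cytotoxicity, read by luminescence, with a stated time of 24 h (on this read-out lower numbers stand for higher toxicity in this test and higher numbers for lower toxicity in this test), compound 1 `CCCNC(=O)C1CCN(C(=O)c2cc3sc(C(C)=O)cc3n2Cc2ccc(OC)cc2)CC1` reads > 100000 nM as a limit of the assay and not a number. Compound 2 `CCCNC(=O)C1CCN(C(=O)c2cc3sc(CO)cc3n2Cc2ccc(OC)cc2)CC1` gives 15500 nM as the only number shown so far. Compound 3 `CCCNC(=O)C1CCN(C(=O)c2cc3sc(C#N)cc3n2Cc2ccc(OC)cc2)CC1` carries cyano in place of hydroxymethyl on an aromatic carbon next to the ring sulfur. Among the compounds with values here, the one measured step bearing on this change is an at least 6.4-fold lower number from compound 1 to compound 2 (0.80 log units; beyond the scatter) on going from acetyl to hydroxymethyl. With hydroxymethyl leaving again, a modest rise is expected in this assay as a 2.3-fold higher number from compound 2 to compound 3 (0.35 log units; beyond the scatter) here. Compound 3 is estimated at 35000 nM with a range of 12000 nM to 100000 nM for now.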

Compound 3, half-maximal cytotoxic concentration: > 100000 nM
Compound 3: a limit, no number; the forecaster's own chance of this, stated with the estimate: 30%; middle value at least 2.8-fold (0.45 log units) away from the limit.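

In this assay, cyano in place of hydroxymethyl on an aromatic carbon next to the ring sulfur gives an at least 6.4-fold higher number from compound 2 to compound 3 (0.80 log units; beyond the scatter). Of the three groups shown at this position, only hydroxymethyl gives a measured number, while acetyl and cyano both leave a limit of the assay rather than a number. The step between compound 1 and compound 3 cannot be read because both compounds sit at that limit: the limit of > 100000 nM in this assay, at which 2 of the 3 values shown sit.

As far as these compounds go, whether an aminomethyl or a carboxylic acid at this position would also give a measured number remains open. From the compounds shown here alone, how far compound 1 and compound 3 lie beyond the limit also remains open.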